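Swapping methoxy for methyl on the aromatic ring

The source may hold more compounds than are shown below. What is called first, only, known or untested is meant among the compounds shown, and "the series" means these compounds.

Three related compounds have been tested in a functional assay on IMR-32 cells (Homo sapiens) for cytotoxicity, read by sulforhodamine B assay, with a stated time of 48 h; on this read-out higher numbers stand for weaker inhibition and lower numbers for stronger inhibition. Compound 3 `COc1ccccc1/C=C/C(=O)/C=C/C1=C(C)CCCC1(C)C` gives 19200 nM, the second highest of the three numbers. Compound 1 `COc1ccc(/C=C/C(=O)/C=C/C2=C(C)CCCC2(C)C)cc1` gives 23900 nM, and compound 2 `CC1=C(/C=C/C(=O)/C=C/c2ccccc2Cl)C(C)(C)CCC1` gives 13700 nM. All three numbers lie within the usual scatter of one another, so none of these compounds can be called stronger or weaker than the others. Within the data shown here, the one measured step that changes a single group on the aromatic ring, methoxy in place of chloro, was a 1.4-fold higher number from compound 2 to compound 3 (0.15 log units; within the scatter).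

Compound 4 `CC1=C(/C=C/C(=O)/C=C/c2ccccc2C)C(C)(C)CCC1` is the next compound. It differs from compound 3 by methyl in place of methoxy on an aromatic carbon. Among the measured compounds shown here, no measured step shows exactly this exchange. For the measured compounds named here, the only step that touches the same aromatic carbon, a 1.4-fold higher number from compound 2 to compound 3 (0.15 log units; within the scatter), stayed within the scatter. Because that step, a 1.4-fold higher number from compound 2 to compound 3 (0.15 log units; within the scatter), was small, the expected step in this assay is a 1.1-fold lower number from compound 3 to compound 4 (0.03 log units; within the scatter), with nothing beyond the scatter. Compound 4 is therefore estimated at 18000 nM, within a range from 8000 nM to 40000 nM.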

Compound 4, half-maximal inhibitory concentration: 63200 nM
For compound 4 the middle estimate is 3.5-fold (0.55 log units) below the measured one; measured number outside the range, above it.
By their numbers in this assay, from the lowest: compounds 2, 3 and 1 (each within the scatter of the next); then compound 4.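

In this assay this aromatic carbon, ortho to a large group, does respond to what it carries: methyl gives a 3.3-fold higher number from compound 3 to compound 4 (0.52 log units; beyond the scatter) and, against chloro, a 4.6-fold higher number from compound 2 to compound 4 (0.66 log units; beyond the scatter) as well. The earlier exchange at this carbon, a 1.4-fold higher number from compound 2 to compound 3 (0.15 log units; within the scatter), stayed within the scatter, so methoxy and chloro cannot be told apart here, while methyl stands apart from both with the weaker inhibition. Nothing available explains why methyl behaves differently from the other two groups.

The compounds shown leave open whether the weaker inhibition belongs to methyl alone or would also appear with other groups on this carbon, such as an amine or trifluoromethyl. They also leave open whether methyl on another carbon of the same ring would give a step of similar size.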